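Thiophen-3-yl in place of 4-methoxyphenyl on the shared core

A few compounds are considered here, and "the series" means these few. Any claim that something is new, unique, unknown or untested is made for them only; others in the source may bear on it.

Measured compounds:
Compound 1 `COc1ccc(-c2cccc3c(Cl)c(Br)c(C(F)(F)F)nc23)cc1`; in an assay for inhibition of ectonucleoside triphosphate diphosphohydrolase 3 (Homo sapiens), read by malachite green, with a stated time of 10 min (on this read-out lower numbers stand for stronger inhibition and higher numbers for weaker inhibition), compound 1 gives > 300000 nM, which is a limit of the assay and not a number.
Compound 2 `FC(F)(F)c1ccc(-c2cccc3c(Cl)c(Br)c(C(F)(F)F)nc23)cc1`; in this assay compound 2 gives > 300000 nM, again a limit of the assay rather than a number.

Compound 1 therefore stands only at a limit in this assay, with no measured inhibition to place it. For the measured compounds named here, the one measured step, trifluoromethyl in place of methoxy on an aromatic carbon, is a step that the two limits leave unreadable from compound 1 to compound 2; both of its values rest at the limit of > 300000 nM in this assay, at which 2 of the 2 values shown sit, so its size cannot be read.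

Compound 3 `FC(F)(F)c1nc2c(-c3ccsc3)cccc2c(Cl)c1Br` differs from compound 1 by thiophen-3-yl in place of 4-methoxyphenyl on an aromatic carbon. Going by the values given here, no measured step touches this change, and the only comparison available, between compound 1 and compound 2, shows two limits and nothing more. The expectation for compound 3 in this assay is therefore another limit, the step from compound 1 being estimated as a step that the limit leaves unreadable from compound 1 to compound 3. Compound 3 is estimated at 400000 nM, with a range from 50000 nM to 3000000 nM.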

Compound 3, half-maximal inhibitory concentration: > 300000 nM
Compound 3 gave a limit, no number; the forecaster's own chance of this, stated with the estimate: 80%; the middle value does not contradict the limit.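

The step from compound 1 to compound 3 cannot be read, and no other new step arises, since both values are limits and not numbers: the limit of > 300000 nM in this assay, at which 3 of the 3 values shown sit.

The compounds shown leave open which change on the shared core, if any, would give a measurable inhibition in this assay.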